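This account rests on a few compounds, and the source may have more. Where it says the series, first, only, none or still open, it means among the compounds named here.

The three measured compounds and their numbers:

compound 1, `N#C[Se]c1ccc(NC(=O)OCc2ccc([N+](=O)[O-])cc2)cc1` — 40700 nM
compound 2, `N#C[Se]c1ccc(NC(=O)Oc2ccc(F)cc2)cc1` — 33300 nM
compound 3, `O=C(Nc1ccc([Se][Se]c2ccc(NC(=O)OCc3ccc([N+](=O)[O-])cc3)cc2)cc1)OCc1ccc([N+](=O)[O-])cc1` — 52800 nM

In a functional assay on MCF7 cells (Homo sapiens) for cytotoxicity, read by MTT assay, with a stated time of 72 h (on this read-out higher numbers stand for weaker inhibition of growth and lower numbers for stronger inhibition of growth), compound 2 gives 33300 nM and so holds the lowest of the three numbers, yet its gap to compound 1 at 40700 nM and to compound 3 at 52800 nM stays within the scatter, so the three compounds cannot be set in any order on this read-out. None of them inhibits growth strongly in this assay.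

Compound 4, `N#C[Se]c1ccc(NC(=O)Oc2ccccc2)cc1`, is the next compound to be tested. It differs from compound 2 in one place: hydrogen in place of fluoro on an aromatic carbon. Within the data shown here, no pair of measured compounds shows this kind of change, so nothing in the present numbers tells how such an exchange moves the read-out; what can be said rests on compound 2 alone.

Given that, the step from compound 2 to compound 4 is expected to be small, with no shift beyond the scatter in either direction, and the expected step is a 1.1-fold higher number from compound 2 to compound 4 (0.02 log units; within the scatter). Compound 4 is therefore estimated to give 35000 nM in this assay, with a range from 15000 nM to 80000 nM, which is close to what compound 2 shows.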

Compound 4, concentration for total growth inhibition in the MCF7 assay: 35900 nM
Compound 4: middle estimate off by 1.0-fold (0.01 log units), on the low side; the measured number falls inside the stated range.
By their numbers in the MCF7 assay, from the lowest: compounds 2, 4, 1 and 3 (each within the scatter of the next).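

This is the first step among the compounds shown that changes a single place, and it concerns the aromatic carbon para to a large group. In the MCF7 assay, hydrogen in place of fluoro gives a 1.1-fold higher number from compound 2 to compound 4 (0.03 log units; within the scatter), so this exchange leaves the number within the scatter. In a physicochemical assay, with a stated time of 6 min, tested at 0.1 mg/mL (a lower number here means less inhibition, a higher number more inhibition at the concentration tested (going by the name of the read-out)), compound 2 gives > 25%, which is a limit of the assay and not a number.

Going by these compounds, in the physicochemical assay, compound 4 gives > 25%, again a limit, so the step between the two cannot be read there, and this read-out adds no comparison of the exchange: the limit of > 25% in the physicochemical assay, at which 2 of the 2 values shown sit. What remains open is whether changes other than this one at this place also leave the number level, since the only two substituents compared here are fluoro and hydrogen, and an amine, a carboxylic acid or a longer chain on the same aromatic carbon might still move the number in the MCF7 assay beyond the scatter.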